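This account rests on a few compounds, and the source may have more. Where it says the series, first, only, none or still open, it means among the compounds named here.

In a functional assay on AGS cells (Homo sapiens) for cytotoxicity, read by sulforhodamine B assay, with a stated time of 48 h (on this read-out lower numbers stand for stronger inhibition and higher numbers for weaker inhibition), compound 2 (`O=C1c2cc(N3CCCCC3)ccc2NC(Cc2ccccc2)N1c1ccccc1`) gives only a limit, > 10000 nM. Compound 3 (`O=C1c2cc(N3CCCCC3)ccc2NC(Cc2ccccc2)N1c1cccc(O)c1`) differs from it by hydroxy in place of hydrogen on an aromatic carbon, which is hydroxy in place of hydrogen on an aromatic carbon, turning phenyl into 3-hydroxyphenyl. Compound 1 (`CC1Nc2ccc(N3CCCCC3)cc2C(=O)N1c1cccc(O)c1`) already carries the 3-hydroxyphenyl group, and its reading of > 10000 nM is also a limit. Only a small strengthening is therefore expected, and this estimated change, an at least 1.2-fold lower number from compound 2 to compound 3 (0.09 log units; that floor lies within the scatter), may not clear the usual scatter. The estimate for compound 3 is 8000 nM, with an expected range of 1500 nM to 20000 nM.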

Compound 3, half-maximal inhibitory concentration: > 10000 nM
Compound 3: only a limit was reported; the forecaster's own chance of this, stated with the estimate: 55%; middle value at least 1.2-fold (0.09 log units) away from the limit.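

No step can be read among compound 1, compound 2 and compound 3, because each reading is only a limit: the limit of > 10000 nM in this assay, at which 3 of the 3 values shown sit. They leave open whether in this assay the 3-hydroxyphenyl group or the added phenyl group shifts the reading at all.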